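A few compounds are considered here, and "the series" means these few. Any claim that something is new, unique, unknown or untested is made for them only; others in the source may bear on it.

Measured so far:
Compound 1, `Fc1ccc(Oc2ccnc3ccsc23)cc1`, 98500 nM
Compound 2, `COc1cccc(Oc2ccnc3ccsc23)c1`, 1560 nM
Compound 3, `COc1ccc(Oc2ccnc3ccsc23)cc1`, 93300 nM

In a functional assay on MCF7 cells (Homo sapiens) for inhibition, read by sulforhodamine B assay, with a stated time of 48 h (a higher number here means a weaker inhibitor of growth, a lower number a stronger inhibitor of growth), compound 2 gives the lowest number of the three, and both other numbers lie beyond the scatter from it. Compound 2 and compound 3 are built from the same atoms joined differently; the difference between the two cores is not broken down here. Between compound 3 and compound 1 the change is fluoro in place of methoxy on an aromatic carbon, and it gave a 1.1-fold higher number from compound 3 to compound 1 (0.02 log units; within the scatter).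

Compound 4, `Fc1cccc(Oc2ccnc3ccsc23)c1`, differs from compound 2 by fluoro in place of methoxy on an aromatic carbon. This is the same kind of change as from compound 3 to compound 1, but the place differs: there para to a large group, here meta to a large group. Resting on a 1.1-fold higher number from compound 3 to compound 1 (0.02 log units; within the scatter), a comparably small step is expected, a 1.9-fold higher number from compound 2 to compound 4 (0.28 log units; within the scatter). For compound 4 an estimate of 3000 nM is given, with a range of 800 nM to 12000 nM.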

Compound 4, concentration for 50% growth inhibition: 102000 nM
For compound 4 the middle estimate is 34-fold (1.53 log units) below the measured one; the measured number lies above the stated range.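

In this assay, the change from methoxy to fluoro gave a 65-fold higher number from compound 2 to compound 4 (1.82 log units; beyond the scatter), and the two cores do not respond alike: the same change on two cores in this assay, a 1.1-fold higher number (0.02 log units; within the scatter) from compound 3 to compound 1 and a 65-fold higher number (1.82 log units; beyond the scatter) from compound 2 to compound 4, 62-fold (1.79 log units) apart, beyond the scatter of two such steps

This shows that, in this series, a step measured on one core need not hold on another. It does not show what lies behind the gap, and two steps give no rule for any further core.

The compounds shown leave open whether the lower number of compound 2 is particular to methoxy. An ethoxy group, a hydroxyl, an amine or a carboxylic acid in the same place might tell whether other groups keep that number or lose it.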